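This account rests on a few compounds, and the source may have more. Where it says the series, first, only, none or still open, it means among the compounds named here.

Measured compounds:
compound 1, `O=C(Nc1cc(-c2ccccc2)nn1-c1ccccc1)c1ccccc1` — 4180 nM
compound 2, `O=C(Nc1cc(-c2ccccc2)nn1-c1ccccc1)c1ccc(OC(F)(F)F)cc1` — 265 nM

In an assay on HEK293 cells for displacement of a labelled ligand from metabotropic glutamate receptor 5 (Rattus norvegicus) (on this read-out higher numbers stand for weaker inhibition and lower numbers for stronger inhibition), compound 1 gives 4180 nM, the highest of the two numbers; its nearest neighbour is compound 2, which gives 265 nM. For the measured compounds named here, the one measured step, a 16-fold lower number from compound 1 to compound 2 (1.20 log units; beyond the scatter), is large and lies beyond the scatter, but it concerns trifluoromethoxy on the benzoyl ring.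

Compound 3, `O=C(Nc1cc(-c2ccccc2)nn1-c1ccccc1Cl)c1ccccc1`, is the step from compound 1 by chloro in place of hydrogen on an aromatic carbon, the change being ortho to a large group on the phenyl attached to the core nitrogen. Going by the values given here, no measured pair changes this ring, so the step from compound 1 to compound 2 bears on it only as a sign that single substituents can move this read-out strongly. Its direction cannot be read from the data. Compound 3 is therefore expected to give 3000 nM, with a range of 700 nM to 13000 nM. This estimate means a step of a 1.4-fold lower number from compound 1 to compound 3 (0.14 log units; within the scatter), expected to fall within the scatter.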

Compound 3, inhibition constant: 500 nM
Estimate against measurement, compound 3: 6.0-fold (0.78 log units) above; measured number below the stated range.
By their numbers in this assay, from the lowest: compounds 2 and 3 (each within the scatter of the next); then compound 1.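

In this assay, the change from phenyl to 2-chlorophenyl, with the chloro ortho to a large group, brings an 8.4-fold lower number from compound 1 to compound 3 (0.92 log units; beyond the scatter) and so shows that this ring also responds to a single substituent, not only the benzoyl ring of compound 2. The step lies beyond the scatter and runs towards stronger inhibition, the same direction as the trifluoromethoxy change on the other ring. No measurement at hand offers a reason for this step.

The compounds shown leave open whether a fluoro, methyl or methoxy group in place of the chloro would move the number in the same way, and whether chloro elsewhere on this ring would do so. They also leave open whether the chloro and the trifluoromethoxy changes would add together in a single compound.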